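Swapping Amino for Nitro on a Cinnamamide Benzophenone

The source may hold more compounds than are shown below. What is called first, only, known or untested is meant among the compounds shown, and "the series" means these compounds.

Measured compounds:
compound 1, `COc1ccc(C(=O)c2cc(OC)c(OC)c(OC)c2)cc1NC(=O)/C=C/c1ccc(F)cc1`: 3200 nM
compound 2, `COc1ccc(C(=O)c2cc(OC)c(OC)c(OC)c2)cc1NC(=O)/C=C/c1ccc(N)cc1`: 15900 nM

Both values come from a functional assay on PC-3 cells (Homo sapiens) for cytotoxicity, read by MTT assay, with a stated time of 72 h; a higher number here means a weaker inhibitor, a lower number a stronger inhibitor. Compound 2 gives the highest of the two numbers, its nearest neighbour being compound 1, which differs only by carrying fluoro where compound 2 carries amino; that step, a 5.0-fold higher number from compound 1 to compound 2 (0.70 log units; beyond the scatter), lies beyond the scatter. Compound 3, `COc1ccc(C(=O)c2cc(OC)c(OC)c(OC)c2)cc1NC(=O)/C=C/c1ccc([N+](=O)[O-])cc1`, differs from compound 2 by nitro in place of amino on an aromatic carbon. For the measured compounds named here, the only measured step that touches this position is the one from compound 1 to compound 2, and it shows that a change at this place can move the number by a modest amount. Going by the values given here, no measured compound carries nitro, so the direction for compound 3 is uncertain; the expected step in this assay is a 3.2-fold lower number from compound 2 to compound 3 (0.50 log units; beyond the scatter). Compound 3 is therefore estimated at 5000 nM, with a range from 1500 nM to 16000 nM.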

Compound 3, half-maximal inhibitory concentration: 10400 nM
For compound 3 the middle estimate is 2.1-fold (0.32 log units) below the measured one, and the stated range covers the measured number.
By their numbers in this assay, from the lowest: compound 1; then compounds 3 and 2 (each within the scatter of the next).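

In this assay, amino and nitro on this aromatic carbon cannot be told apart: the swap gives a 1.5-fold lower number from compound 2 to compound 3 (0.18 log units; within the scatter). The two groups differ in heavy atoms and hydrogen-bond donors, yet that difference leaves no reading beyond the scatter here, whereas fluoro remains clearly separate, with a 3.3-fold higher number from compound 1 to compound 3 (0.51 log units; beyond the scatter). Nothing available explains why fluoro stands apart from the other two groups.

Only three groups at this position are shown, so it remains open whether the lower number of compound 1 is special to fluoro or would be shared by other small groups such as chloro or a plain hydrogen. Going by these compounds, whether a methoxy group or a carboxylic acid in the same place would fall with fluoro, with amino and nitro, or elsewhere also remains open.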